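The compounds below may be only part of what the source reports. "The series", "measured", "known", "first", "only" and "open" are said of these compounds alone.

Values in an ADME assay on MONO-MAC-6 cells (Homo sapiens) for cytotoxicity, read by MTT assay, with a stated time of 16 h; on this read-out lower numbers stand for stronger inhibition and higher numbers for weaker inhibition:

compound 1 `O=C(c1ccccc1)c1ccc(NC(=O)c2cc(Br)ccc2O)cc1`: 21800 nM
compound 2 `O=C(NCCCCl)Oc1ccc(Br)cc1C(=O)Nc1ccc(C(F)(F)F)cc1`: 5700 nM
compound 3 `O=C(NCCCCl)Oc1ccc(Cl)cc1C(=O)Nc1ccc(C(=O)c2ccccc2)cc1`: 16100 nM

Compound 3 stands second highest of the three numbers in this assay. Its nearest neighbour is compound 1, whose value lies within the scatter of it, so no order between these two can be read. The furthest is compound 2, whose value lies beyond the scatter, a lower number than that of compound 3.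

For the measured compounds named here, none of the measured compounds differ from one another in a single place, so no measured step of any kind is available to lean on.

Compound 4 `O=C(NCCCCl)Oc1ccc(Br)cc1C(=O)Nc1ccc(C(=O)c2ccccc2)cc1` is not yet measured. It differs from compound 3 in one place: bromo in place of chloro on an aromatic carbon. Going by the values given here, the only guide is that compound 3 gives 16100 nM in this assay and that the change exchanges one halogen for another at the same place.

For compound 4 no step beyond the scatter is expected in this assay, in either direction. The estimate for compound 4 is 16000 nM, with a range from 8000 nM to 32000 nM, which means an expected step of a 1.0-fold lower number from compound 3 to compound 4 (0.00 log units; within the scatter).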

Compound 4, half-maximal inhibitory concentration: 12600 nM
For compound 4 the middle estimate is 1.3-fold (0.10 log units) above the measured one, within the range that was stated.
By their numbers in this assay, from the lowest: compound 2; then compounds 4, 3 and 1 (each within the scatter of the next).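

In this assay, the exchange of halogen at this place, para to a ((3-chloropropyl)carbamoyl)oxy group, gives a step within the scatter (a 1.3-fold lower number from compound 3 to compound 4 (0.11 log units; within the scatter)), so bromo and chloro cannot be told apart here with the benzoyl group in place. For the compounds shown here, with bromo held fixed, benzoyl in place of trifluoromethyl is the only one of the new steps beyond the scatter, and it is modest (a 2.2-fold higher number from compound 2 to compound 4 (0.34 log units; beyond the scatter)), while (3-chloropropyl)carbamoyl in place of hydrogen on the oxygen stays within it (a 1.7-fold lower number from compound 1 to compound 4 (0.24 log units; within the scatter)). No measurement on hand bears on the reason for any of these steps.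

Only two halogens appear at this place, both on the same shared core, so the reading rests on a single pair. On these data alone, how an amine, a carboxylic acid or a longer chain at this place would read remains open.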